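Working notes: pyridin-4-yl for 4-methoxyphenyl

The source may report more compounds than this note shows. Statements on the series, on what has been measured and on what is new or still open speak of the compounds shown alone.

- Compound 1 `CC(C)(C)n1cc2c(n1)C(=O)CC1(CCN(C(=O)c3cc(-c4ccccc4)nc4ccccc34)CC1)O2`: 2110 nM
- Compound 2 `COc1ccc(-c2cc(C(=O)N3CCC4(CC3)CC(=O)c3nn(C(C)(C)C)cc3O4)c3ccccc3n2)cc1`: 2780 nM
- Compound 3 `CN(C)c1ccc(-c2cc(C(=O)N3CCC4(CC3)CC(=O)c3nn(C(C)(C)C)cc3O4)c3ccccc3n2)cc1`: 1730 nM

In a functional assay on HepG2 cells (Homo sapiens) for inhibition, read by MTT assay, with a stated time of 72 h (a lower number here means a stronger inhibitor, a higher number a weaker inhibitor), compound 2 gives 2780 nM, which stands within the scatter of compound 1 and compound 3. Compound 4 `CC(C)(C)n1cc2c(n1)C(=O)CC1(CCN(C(=O)c3cc(-c4ccncc4)nc4ccccc34)CC1)O2` carries pyridin-4-yl in place of 4-methoxyphenyl on an aromatic carbon. Going by the values given here, the steps that bear on this are a 1.3-fold higher number from compound 1 to compound 2 (0.12 log units; within the scatter), a 1.2-fold lower number from compound 1 to compound 3 (0.09 log units; within the scatter) and a 1.6-fold lower number from compound 2 to compound 3 (0.21 log units; within the scatter). Among the compounds with values here, all three alter the phenyl group on that carbon, and none replaces its ring, so the data hold no direct precedent. Going by these steps, no change beyond the scatter is expected in this assay. The expected step is a 1.1-fold lower number from compound 2 to compound 4 (0.05 log units; within the scatter). The estimate for compound 4 is 2500 nM, with an expected range of 1100 nM to 6000 nM.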

Compound 4, half-maximal inhibitory concentration: 380 nM
Compound 4: the middle estimate sits 6.6-fold (0.82 log units) above what was measured, and the stated range ends above it.
By their numbers in this assay, from the lowest: compound 4; then compounds 3, 1 and 2 (each within the scatter of the next).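

In (this assay) replacing the whole ring on this carbon matters where changing the substituent on the phenyl ring did not: pyridin-4-yl for 4-methoxyphenyl gives (a 7.3-fold lower number from compound 2 to compound 4 (0.86 log units; beyond the scatter)). Pyridin-4-yl also stands apart from 4-(dimethylamino)phenyl (a 4.6-fold lower number from compound 3 to compound 4 (0.66 log units; beyond the scatter)) and from unsubstituted phenyl (a 5.6-fold lower number from compound 1 to compound 4 (0.74 log units; beyond the scatter)), so removing the substituent alone does not reproduce the step. Nothing measured here explains it.

On these data alone, whether pyridin-3-yl or pyridin-2-yl on this carbon keeps the lower number remains open. So does the outcome with a pyrimidin-5-yl ring.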